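The source may hold more compounds than are shown below. What is called first, only, known or untested is meant among the compounds shown, and "the series" means these compounds.

Working notes on the series. In a functional assay on MCF7 cells (Homo sapiens) for inhibition, read by fluorescence, with a stated time of 72 h (on this read-out lower numbers stand for stronger inhibition of growth and higher numbers for weaker inhibition of growth), compound 1 `Cc1nc(CCO)cc2nn(-c3ccccc3)cc12` gives > 100000 nM, which is a limit of the assay and not a number. Compound 3 `OCCc1cc2nn(-c3ccccc3)cc2cn1` likewise gives > 100000 nM, also a limit. The step that the two limits leave unreadable from compound 1 to compound 3 is therefore not readable in size. Going by the values given here, compound 2 `CCCCc1cc2nn(-c3ccccc3)cc2c(C(C)C)n1` differs from compound 1 in more than one place; in this assay compound 2 gives 33300 nM, the only number in the set. Compound 1 thus stands at the limit of > 100000 nM in this assay, at which 2 of the 3 values shown sit; nothing places it above or below compound 3, and only compound 2 shows that the series can reach a measurable value in this assay.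

The compound to be measured is compound 4 `Cc1nc(-c2ccccc2)cc2nn(-c3ccccc3)cc12`. Its change from compound 1 is phenyl in place of 2-hydroxyethyl on an aromatic carbon. No measured step shares this change: the single step shown, a step that the two limits leave unreadable from compound 1 to compound 3, concerns a different site and is unreadable, and the gap between compound 1 and compound 2 is not a single step. The expectation therefore rests only on compound 2 reaching a number at 33300 nM while compound 1 does not. The step of an at least 1.6-fold lower number from compound 1 to compound 4 (0.22 log units; that floor lies within the scatter) is expected to be at most modest, with a real chance of no readable step at all. Compound 4 is estimated at 60000 nM, within 15000 nM to 200000 nM.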

Compound 4, concentration for 50% growth inhibition: 11000 nM
Compound 4: middle estimate off by 5.5-fold (0.74 log units), on the high side; measured number outside the range, below it.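

In this assay, the position on the aromatic carbon next to the ring nitrogen is one where a single change moves the read-out: phenyl in place of 2-hydroxyethyl gives an at least 9.0-fold lower number from compound 1 to compound 4 (0.95 log units; beyond the scatter). Going by these compounds alone, the only earlier single-place step, at the methyl site, cannot be read, so this is the first evidence tied to one site, and here the methyl group stays unchanged while the core of compound 1 reaches a measured number. The size of this step is only a floor, since the value of compound 1 is a limit of the assay and not a number: the limit of > 100000 nM in this assay, at which 2 of the 4 values shown sit.

The change swaps a chain with a hydrogen-bond donor and acceptor for an aromatic ring of carbon only with neither, and the compounds shown do not separate the contribution of the ring, the larger group or the loss of the hydroxyl. An ethyl group, a benzyl group or a pyridyl ring at this position would begin to pull these apart.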